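This account rests on a few compounds, and the source may have more. Where it says the series, first, only, none or still open, it means among the compounds named here.

Compound 1 `FC(F)(F)c1ccc(-c2nn(-c3ccccc3)cc2-c2nc3ccccc3[nH]2)cc1`: 4670 nM
Compound 2 `Cc1ccc(-c2nn(-c3ccccc3)cc2-c2nc3ccccc3n2S(=O)(=O)c2cc(C)ccc2C)cc1`: 370 nM

In a functional assay on HeLa cells (Homo sapiens) for antiproliferative activity, read by MTT assay, with a stated time of 24 h (on this read-out higher numbers stand for weaker inhibition and lower numbers for stronger inhibition), compound 2 gives 370 nM, the lower of the two numbers, and compound 1 gives 4670 nM. These two compounds differ in more than one place, so their gap says nothing about a single change. Compound 3 `Cc1ccc(-c2nn(-c3ccccc3)cc2-c2nc3ccccc3n2S(=O)(=O)c2ccc(Br)cc2)cc1` keeps the rest of compound 2 and carries 4-bromophenyl in place of 2,5-dimethylphenyl on a sulfonyl sulfur. Among the measured compounds shown here, no measured pair shows this swap, so no step beyond the scatter is expected. The estimated step is a 1.4-fold higher number from compound 2 to compound 3 (0.13 log units; within the scatter). For compound 3 the expected value is 500 nM, within an estimated range of 180 nM to 1400 nM.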

Compound 3, half-maximal inhibitory concentration: 2340 nM
For compound 3 the middle estimate is 4.7-fold (0.67 log units) below the measured one; measured number outside the range, above it.
By their numbers in this assay, from the lowest: compound 2; then compounds 3 and 1 (each within the scatter of the next).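

The group on the sulfonyl sulfur clearly affects the result: in this assay, 4-bromophenyl in place of 2,5-dimethylphenyl gives a 6.3-fold higher number from compound 2 to compound 3 (0.80 log units; beyond the scatter). Exchanging one carbon-only aromatic ring for another at this position is therefore not a neutral change. Nothing available explains this step.

The compounds shown leave open whether the step follows from losing the two methyl groups, gaining the bromine, or both. As far as these compounds go, how a plain phenyl or a methoxyphenyl on the sulfonyl sulfur would compare also remains open.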